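A Solubility Limit Leaves the Next Step Open

The source may hold more compounds than are shown below. What is called first, only, known or untested is meant among the compounds shown, and "the series" means these compounds.

In a physicochemical assay for solubility, in phosphate buffer (on this read-out lower numbers stand for lower solubility and higher numbers for higher solubility), compound 3 (`Cc1cc(N[C@H](CCCCNCc2ccc([N+](=O)[O-])cc2)C(=O)NO)cc(C)c1F`) gives > 5 ug/mL as a limit, not a number. Compound 1 (`Cc1cc(N[C@H](CCCCN)C(=O)NO)cc(C)c1F`) gives > 5 ug/mL as a limit too. Compound 2 (`Cc1cc(N[C@H](CCCCNCc2ccc(C(F)(F)F)cc2)C(=O)NO)cc(C)c1F`) likewise gives > 5 ug/mL as a limit. Compound 4 (`Cc1cc(N[C@H](CCCCNCCCc2ccc(F)cc2)C(=O)NO)cc(C)c1F`) has 2-(4-fluorophenyl)ethyl in place of 4-nitrophenyl on a saturated chain carbon bound to an amine nitrogen. Two measured changes bear on this, (a step that the two limits leave unreadable from compound 1 to compound 3) and (a step that the two limits leave unreadable from compound 2 to compound 3), but neither has a readable size. So no step beyond the usual scatter is expected in this assay and no direction is foreseen, giving an estimated change of (a step that the limit leaves unreadable from compound 3 to compound 4). Compound 4 is estimated at (7 ug/mL), with an expected range from (3 ug/mL) to (30 ug/mL).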

Compound 4, solubility: > 5 ug/mL
Compound 4: no number, only a limit (the forecaster's own chance of this, stated with the estimate: 85%); the middle value does not contradict the limit.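

Compound 4 gives only a limit, as do compound 1, compound 2 and compound 3, so no step among them can be read in this assay: the limit of > 5 ug/mL in this assay, at which 4 of the 4 values shown sit.

From the compounds shown here alone, how these four compounds truly rank in this assay, and whether any of their substitutions shifts the read-out at all, stays open.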